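A few compounds are considered here, and "the series" means these few. Any claim that something is new, unique, unknown or untested is made for them only; others in the source may bear on it.

Measured compounds in a functional assay on HEK293 cells for agonist activity at Nucleotide-binding oligomerization domain-containing protein 1 (Homo sapiens), read by spectrophotometry; on this read-out higher numbers stand for an effect only at larger amounts of compound and lower numbers for an effect already at smaller amounts:
- compound 1, `CCCCCCCCCCCC(=O)N[C@H](CCC(=O)NC(CCCC(N)C(=O)O)C(=O)O)C(=O)O`: 0.027 nM
- compound 2, `CCCCCCCCCCCCN[C@H](CCC(=O)NC(CCCC(N)C(=O)O)C(=O)O)C(=O)O`: 0.023 nM
- compound 3, `CCCCCCCCN(CCCCCCCC)[C@H](CCC(=O)NC(CCCC(N)C(=O)O)C(=O)O)C(=O)O`: 0.2 nM

Compound 1 stands second highest of the three numbers. Its gap to compound 2 is within the scatter, so the two cannot be ordered. Compound 3 gives a number above compound 1 beyond the scatter; the two differ at the nitrogen on the dodecyl side, not at any other place. Among the measured compounds shown here, no pair of measured compounds differs in one place only, so no measured step can be read as a clean single change.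

Compound 4, `CCCCCCCCCCCC(=O)N[C@H](CCC(=O)NC(CCCC1NC(N)=NC1=O)C(=O)O)C(=O)O`, differs from compound 1 by a group of 7 heavy atoms (3 carbon, 3 nitrogen, 1 oxygen; one five-membered non-aromatic ring with 2 hetero atoms) in place of a group of 5 heavy atoms (2 carbon, 1 nitrogen, 2 oxygen; no ring), on a saturated chain carbon, four bonds along the chain from an amide-type nitrogen and a carbonyl carbon. All three measured compounds carry the amino(carboxy)methyl group unchanged at this place, so nothing measured bears on what its replacement does; the expectation rests on the structural change alone. The chain carbon four bonds along from the amide-type nitrogen and the carbonyl carbon is left untouched in every measured compound, while the group on it is rebuilt into a ring here. A step toward higher numbers beyond the scatter is expected, with wide uncertainty. For compound 4 the estimated value is 10 nM, with a range from 0.5 nM to 300 nM. The expected step is a 370-fold higher number from compound 1 to compound 4 (2.57 log units; beyond the scatter).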

Compound 4, half-maximal effective concentration: 1.31 nM
Beside the measured number, compound 4's estimate is 7.6-fold (0.88 log units) above it; the range from low to high includes it.
By their numbers in this assay, from the lowest: compounds 2 and 1 (each within the scatter of the next); then compound 3; then compound 4.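

In this assay, the rebuilding of the amino(carboxy)methyl group into a five-membered non-aromatic ring with 2 hetero atoms, on a saturated chain carbon, four bonds along the chain from an amide-type nitrogen and a carbonyl carbon, gives a 49-fold higher number from compound 1 to compound 4 (1.69 log units; beyond the scatter), the first measured sign that this position responds to a change of group. The open-chain group is still not a strict requirement for a response, since compound 4 gives a measurable half-maximal concentration of 1.31 nM. Nothing in hand accounts for the size of this step.

Among the compounds shown here, the single step cannot separate the contribution of the ring from that of the other atoms exchanged, and a plain primary amine, a carboxylic acid or a methyl ester at the same chain carbon would be needed to divide it into parts. As far as these compounds go, whether the ring group would bring a step of similar size on the core of compound 2 or compound 3, which carry a dodecylamine and a dioctylamine side instead of the dodecanoyl amide, also remains open.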